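A few compounds are considered here, and "the series" means these few. Any claim that something is new, unique, unknown or untested is made for them only; others in the source may bear on it.

Measured so far:
- compound 1, `COc1ccc(OC)c(/C=C/c2nnc(Nc3ccc(Cl)cc3)o2)c1`: 7680 nM
- compound 2, `COc1ccc(OC)c(/C=C/C(=O)N/N=C/c2ccc(Cl)cc2)c1`: 50200 nM

Of the compounds shown here, two have been tested in a functional assay on HOP-62 cells (Homo sapiens) for antiproliferative activity, read by sulforhodamine B assay, with a stated time of 48 h; on this read-out higher numbers stand for weaker inhibition of growth and lower numbers for stronger inhibition of growth. Compound 1, with its five-membered heteroaromatic ring linking the styryl part to the aniline, gives 7680 nM in this assay. Compound 2, in which that ring is opened into an acylhydrazone chain, gives 50200 nM in this assay, the higher of the two numbers and a gap to compound 1 that lies beyond the usual scatter; compound 2 therefore stands as the weaker of the two measured compounds.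

The next compound, compound 3, `COc1ccc(OC)c(/C=C/C(=O)N/N=C/c2ccccc2)c1`, keeps the whole acylhydrazone framework of compound 2 and differs only at the far end: hydrogen in place of chloro on an aromatic carbon. Going by the values given here, no step of this exact kind has been measured here, so the size of its effect is uncertain; a change this small at the edge of the molecule is expected to move the number little, if at all, beyond the scatter, and the direction cannot be called from these two compounds alone. The expected step is a 1.2-fold higher number from compound 2 to compound 3 (0.08 log units; within the scatter). Compound 3 is therefore estimated at 60000 nM in this assay, with a likely range from 25000 nM to 150000 nM.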

Compound 3, concentration for total growth inhibition: > 100000 nM
Compound 3 was reported as a limit; the forecaster's own chance of this, stated with the estimate: 15%; middle value at least 1.6-fold (0.22 log units) away from the limit.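

In this assay, putting hydrogen in place of the chloro gives an at least 1.9-fold higher number from compound 2 to compound 3 (0.29 log units; that floor lies within the scatter). Going by these compounds alone, this is the first measured step at this place on the ring, para to a large group, and it offers no sign that losing the chloro improves growth inhibition: the number does not fall, even though its floor alone does not show a real loss. The size of the change from 4-chlorophenyl to phenyl cannot be read, because compound 3 is reported only as a limit of the assay and not as a number: the limit of > 100000 nM in this assay, at which 1 of the 3 values shown sits.

From the compounds shown here alone, only chloro and hydrogen have been compared at this position, so it remains open whether a fluoro, a methoxy or an amine there would bring the number down or push it up. Going by these compounds, it is also open whether the same change from 4-chlorophenyl to phenyl would shift the number in the same direction on the core of compound 1, since that step appears here only in the acylhydrazone framework.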